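Replacing Pyridin-4-yl with 3-Hydroxyphenyl: Cytotoxicity Outlook

The source may hold more compounds than are shown below. What is called first, only, known or untested is meant among the compounds shown, and "the series" means these compounds.

Compound 1, `COc1cc(F)cc(-c2ccc(C(=O)N(Cc3cccc(OCCCCCC(=O)O)c3)C(C)C)cc2)c1`. In an ADME assay on HEK293 cells (Homo sapiens) for cytotoxicity, read by CellTiter-Glo and resazurin assay, with a stated time of 72 h (a lower number here means that less compound is needed, a higher number that more compound is needed for the effect), compound 1 gives > 26000 nM, which is a limit of the assay, not a number.
Compound 2, `CC(C)N(Cc1cccc(OCCCCCC(=O)O)c1)C(=O)c1ccc(-c2cccc([N+](=O)[O-])c2)cc1`. In this assay compound 2 gives > 26000 nM, again a limit.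
Compound 3, `CCOC(=O)CCCCCOc1cccc(CN(C(=O)c2ccc(-c3ccncc3)cc2)C(C)C)c1`. In this assay compound 3 gives > 26000 nM, also a limit.

So compound 3 stands at the limit of this assay, as do the other two measured compounds, all three sitting at the limit of > 26000 nM in this assay, at which 3 of the 3 values shown sit. Compound 4, `CCOC(=O)CCCCCOc1cccc(CN(C(=O)c2ccc(-c3cccc(O)c3)cc2)C(C)C)c1`, differs from compound 3 by 3-hydroxyphenyl in place of pyridin-4-yl on an aromatic carbon. For the measured compounds named here, the only measured step, a step that the two limits leave unreadable from compound 1 to compound 2, also swaps one aromatic group on the shared core but runs between two limits and so cannot be read in size or direction. Going by the values given here, no measured step therefore points to a change beyond the scatter, and the expected step is a number no higher from compound 3 to compound 4 (the limit leaves the size open). Compound 4 is estimated at 26000 nM, with a range from 10000 nM to 70000 nM, most likely reported again only as a limit.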

Compound 4, half-maximal effective concentration: > 26000 nM
Compound 4 ended at the assay's limit; the forecaster's own chance of this, stated with the estimate: 75%; the middle value sits exactly at the limit.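

The step between compound 3 and compound 4 cannot be read, because both stand at a limit and not at a number: the limit of > 26000 nM in this assay, at which 4 of the 4 values shown sit.

The compounds shown leave open at what concentration any of them would affect these cells, and whether any change on the shared core would shift that concentration.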